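Cytotoxicity notes: tetrahydronaphthalenyl in place of ethylphenyl

The source may report more compounds than this note shows. Statements on the series, on what has been measured and on what is new or still open speak of the compounds shown alone.

Compound 1 `CCc1ccc(-c2nc3c(c(C)nn3-c3ccccc3)c(-c3ccccc3O)c2C#N)cc1` has been measured in an ADME assay on BJ cells (Homo sapiens) for cytotoxicity, with a stated time of 72 h (a higher number here means that more compound is needed for the effect, a lower number that less compound is needed), only to a limit. In this assay compound 1 gives > 20000 nM, which is a limit of the assay and not a number. Compound 2 `CCc1ccc(-c2nc3c(c(C)nn3-c3ccccc3)c(-c3cccc(O)c3)c2C#N)cc1` likewise gives in this assay > 20000 nM, again a limit and not a number. The step that the two limits leave unreadable from compound 1 to compound 2 is therefore unreadable, and the evidence the limit of > 20000 nM in this assay, at which 2 of the 2 values shown sit, covers every value shown. Compound 3 `Cc1nn(-c2ccccc2)c2nc(-c3ccc4c(c3)CCCC4)c(C#N)c(-c3ccccc3O)c12` is the unmeasured member; it differs from compound 1 by 1,2,3,4-tetrahydronaphthalen-6-yl in place of 4-ethylphenyl on an aromatic carbon. No measured step touches this position, and the one step shown is itself unreadable, so nothing in the data points toward a change in either direction. The step that the limit leaves unreadable from compound 1 to compound 3 is expected to stay within the scatter. Compound 3 is estimated at 30000 nM, with a range from 15000 nM to 60000 nM, and the outcome is expected to be reported as a limit.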

Compound 3, half-maximal effective concentration: > 20000 nM
Compound 3: a limit, no number; the forecaster's own chance of this, stated with the estimate: 85%; the middle value lies beyond the limit too.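

In this assay, among these compounds, compound 1 and compound 3 both give a limit and not a number, so no step between them can be read: the limit of > 20000 nM in this assay, at which 3 of the 3 values shown sit.

The compounds shown leave open whether 1,2,3,4-tetrahydronaphthalen-6-yl in place of 4-ethylphenyl changes the concentration needed for the half-maximal effect at all.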